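Methoxy to Fluoro on the Sulfonyl Aryl Ring

This account rests on a few compounds, and the source may have more. Where it says the series, first, only, none or still open, it means among the compounds named here.

Compound 1 `COc1ccc(S(=O)(=O)c2cnc3c(F)cccc3c2-c2cccc(F)c2)cc1` gives 3.03 mL/min in an ADME assay on microsomes from liver (Homo sapiens) for metabolic stability, tested at 2.5 uM (a higher number here means faster removal of the compound, a lower number slower removal), the higher of the two numbers recorded so far, while compound 2 `COc1ccc(S(=O)(=O)c2cnc3c(F)cccc3c2-c2ccc(Cl)cc2)cc1` gives 1.05 mL/min. For the measured compounds named here, the single measured step, a 2.9-fold lower number from compound 1 to compound 2 (0.46 log units; beyond the scatter), concerns the other aryl ring and does not bear on the change now in question. Compound 3 `O=S(=O)(c1ccc(F)cc1)c1cnc2c(F)cccc2c1-c1cccc(F)c1` differs from compound 1 by fluoro in place of methoxy on an aromatic carbon. Going by the values given here, with no measured step informing this change, compound 3 is expected to show a 1.7-fold lower number from compound 1 to compound 3 (0.23 log units; within the scatter), leaning lower but with the direction uncertain. The estimate for compound 3 is 1.8 mL/min, between 0.8 mL/min and 4 mL/min.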

Compound 3, intrinsic clearance in a liver preparation (reported as CLH), per the amount of preparation that the assay uses: 1.56 mL/min
Beside the measured number, compound 3's estimate is 1.2-fold (0.06 log units) above it; the measured number falls inside the stated range.
By their numbers in this assay, from the lowest: compounds 2, 3 and 1 (each within the scatter of the next, the first and the last beyond it).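

In this assay, fluoro in place of methoxy on an aromatic carbon, para to a large group, gives a 1.9-fold lower number from compound 1 to compound 3 (0.29 log units; within the scatter) and so does not move the number beyond the usual scatter. At this position, then, the 4-methoxyphenyl can give way to the 4-fluorophenyl with the two numbers remaining within scatter of each other. Nothing measured here offers an explanation for this result. The compounds shown leave open whether an amine or a carboxylic acid at this position would also stay within the scatter of compound 1. They also leave open whether the same change would read alike on compound 2.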